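The compounds below may be only part of what the source reports. "The series", "measured", "known", "first", "only" and "open" are said of these compounds alone.

Compound 1 `COc1ccc(-c2cc3ccccc3nc2/C=C/C(=O)c2c(OC)cccc2OC)cc1` gives 7410 nM in a functional assay on A549 cells (Homo sapiens) for antiproliferative activity, read by XTT assay, with a stated time of 72 h (on this read-out lower numbers stand for stronger inhibition and higher numbers for weaker inhibition), and compound 2 `COc1ccc(-c2cc3ccccc3nc2/C=C/C(=O)c2ccc(OC)c(OC)c2)cc1` gives 8860 nM; the step of a 1.2-fold higher number from compound 1 to compound 2 (0.08 log units; within the scatter) stays within the scatter. Compound 3 `COc1ccc(-c2cc3ccccc3nc2/C=C/C(=O)c2sccc2N)cc1` reaches only the limit of this assay, > 10000 nM, so for compound 3 a floor is known rather than a number (the limit of > 10000 nM in this assay, at which 1 of the 3 values shown sits). The steps of an at least 1.3-fold higher number from compound 1 to compound 3 (0.13 log units; that floor lies within the scatter) and an at least 1.1-fold higher number from compound 2 to compound 3 (0.05 log units; that floor lies within the scatter) are accordingly floors as well, and both sit within the scatter. Compound 4 `COc1ccc(-c2cc3ccccc3nc2/C=C/C(=O)c2cnc(N)nc2C)cc1` differs from compound 3 in one place: 2-amino-4-methylpyrimidin-5-yl in place of 3-aminothiophen-2-yl on a carbonyl carbon. Going by the values given here, no measured step places a 2-amino-4-methylpyrimidin-5-yl on the carbonyl carbon, so the two floors running from compound 1 and compound 2 to compound 3 are the only guide, and both are small. The step of a number no higher from compound 3 to compound 4 (the limit leaves the size open) is therefore expected to be small, or none beyond the scatter, with compound 4 remaining near the limit region. Compound 4 is estimated at 10000 nM, with a range from 4000 nM to 25000 nM, and a fair chance that this assay once more reports only a limit.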

Compound 4, half-maximal inhibitory concentration: > 10000 nM
Compound 4 gave a limit, no number; the forecaster's own chance of this, stated with the estimate: 55%; the middle value lies on the limit itself.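

In this assay compound 4 gives > 10000 nM, which is a limit and not a number, so a second aminated heteroaromatic group on this carbonyl carbon now sits at the edge of what can be read: the limit of > 10000 nM in this assay, at which 2 of the 4 values shown sit. The steps of an at least 1.1-fold higher number from compound 2 to compound 4 (0.05 log units; that floor lies within the scatter) and an at least 1.3-fold higher number from compound 1 to compound 4 (0.13 log units; that floor lies within the scatter) are floors only, and neither separates compound 4 from the two dimethoxyphenyl compounds. Putting 2-amino-4-methylpyrimidin-5-yl in place of 3-aminothiophen-2-yl brings no readable value, and the step between compound 3 and compound 4 cannot be read.

On these data alone, how far compound 3 and compound 4 lie past the limit remains open. Also open, as far as these compounds go, is how an unsubstituted phenyl or a 2-aminopyrimidin-5-yl without the methyl would read on this carbonyl carbon.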